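The compounds below may be only part of what the source reports. "The series", "measured", "known", "first", "only" and "open" are said of these compounds alone.

Compound 1 `OCCC(NC1CCN(CCCc2c[nH]c3ccc(-n4cnnc4)cc23)CC1)c1ccccc1` is the reference point of this account. For the measured compounds named here, in a functional assay on CHO cells for activation of 5-hydroxytryptamine receptor 1D (Homo sapiens), read by GTPgammaS binding (on this read-out higher numbers stand for larger maximal responses and lower numbers for smaller maximal responses), compound 1 gives 100%, the highest of the three numbers known. Going by the values given here, its nearest neighbour is compound 3 `CN(Cc1ccccc1)CC1CCN(CCCc2c[nH]c3ccc(-n4cnnc4)cc23)CC1`, which in this assay gives 93%; the only single-site step known, a number 7 percentage points lower from compound 1 to compound 3 (within the scatter), is within the scatter, so the two compounds cannot be ordered. Furthest away is compound 2 `c1ccc(C2CCCCN2C2CCN(CCCc3c[nH]c4ccc(-n5cnnc5)cc34)CC2)cc1`, which in this assay gives 65%, a number below that of compound 1 and beyond the scatter; no single-site step connects compound 2 to compound 1, so only its value can be stated.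

Compound 4 `NC(=O)OC[C@H](NC1CCN(CCCc2c[nH]c3ccc(-n4cnnc4)cc23)CC1)c1ccccc1` has not yet been measured in this assay. It differs from compound 1 in one place: 2-(carbamoyloxy)-1-phenylethyl in place of 3-hydroxy-1-phenylpropyl on an amine nitrogen. Among the compounds with values here, the one measured step that bears on this region, the replacement of the whole substituent on the saturated ring carbon from compound 1 to compound 3, stayed within the scatter. Within the data shown here, the change to compound 4 keeps the amine nitrogen and the phenyl group and alters only the chain carrying the oxygen; no measured step tests exactly this exchange. Compound 4 is therefore expected to show no step beyond the scatter, as the estimated a number 5 percentage points lower from compound 1 to compound 4 (within the scatter) says. The estimate for compound 4 is 95%, with a range from 75% to 110%.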

Compound 4, largest response reached (reported as efficacy), in percent of the reference or control that the assay uses: 73%
For compound 4 the middle estimate is 22 percentage points above the measured one, and the stated range ends above it.
By their numbers in this assay, from the lowest: compounds 2 and 4 (each within the scatter of the next); then compounds 3 and 1 (each within the scatter of the next).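

In this assay the exchange on the amine nitrogen gives a number 27 percentage points lower from compound 1 to compound 4 (beyond the scatter), so this position does respond to a change that keeps the phenyl group and alters only the chain carrying the oxygen. For the compounds shown here, the one earlier single-site step, a number 7 percentage points lower from compound 1 to compound 3 (within the scatter), replaced the whole substituent on the saturated ring carbon and did not leave the scatter, so the earlier compounds gave no sign that the response could shift beyond the scatter within this part of the molecule. No measurement at hand accounts for the lower response of compound 4.

The step changes several things at once: the 3-hydroxy-1-phenylpropyl chain gives way to a 2-substituted ethyl chain, the hydroxyl gives way to carbamoyloxy, and compound 4 carries a defined stereocentre, and the compounds shown do not separate these. On these data alone, it stays open which of them goes with the lower response, and a 2-hydroxy-1-phenylethyl or a 3-(carbamoyloxy)-1-phenylpropyl group on the same amine nitrogen, or the opposite stereocentre of compound 4, would bear on that question.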